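The compounds below may be only part of what the source reports. "The series", "measured", "known", "first", "only" and "open" are said of these compounds alone.

Measured compounds in a functional assay on the whole organism with Rattus norvegicus as the target; on this read-out higher numbers stand for an effect only at larger amounts of compound and lower numbers for an effect already at smaller amounts:
compound 1 `CC1CCC(=NNc2ccccc2C(=O)O)c2ncc(C(=O)NO)c(=O)n21`: > 100 umol/kg
compound 2 `Cc1ccc(NN=C2CCC(C)n3c2ncc(C(=O)O)c3=O)cc1C`: 6.5 umol/kg
compound 3 `CCc1nc2n(c(=O)c1C(=O)O)C(C)CCC2=NNc1ccccc1`: > 100 umol/kg

Among the compounds with values here, of these three values only that of compound 2 is a number. For compound 1 the value > 100 umol/kg in this assay is a limit of the assay, not a number. For compound 3 the value > 100 umol/kg in this assay is likewise a limit. Within the data shown here, two of the three values therefore sit at the limit of > 100 umol/kg in this assay, at which 2 of the 3 values shown sit, and compound 2 with 6.5 umol/kg is the one compound of the set for which a dose could be read at all. Among the measured compounds shown here, no pair of measured compounds differs in a single place, so no measured step exists in this assay to lean on.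

Compound 4 `CNN=C1CCC(C)n2c1ncc(C(=O)O)c2=O` is not yet measured. It differs from compound 2 by methyl in place of 3,4-dimethylphenyl on an amine nitrogen. For the measured compounds named here, the anilino part of the hydrazone is thereby reduced to a methyl, with nothing among the measured compounds showing what this change does.

The expectation for compound 4 is a step of a 9.2-fold higher number from compound 2 to compound 4 (0.97 log units; beyond the scatter) towards weaker activity, well beyond the scatter, with a real chance that only a limit is returned. The estimated value for compound 4 in this assay is 60 umol/kg, within 15 umol/kg to 150 umol/kg.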

Compound 4, dose for 50% inhibition: 17.5 umol/kg
Compound 4: middle estimate off by 3.4-fold (0.54 log units), on the high side; the range from low to high includes it.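

In this assay, within the data shown here, methyl in place of 3,4-dimethylphenyl on an amine nitrogen gives a 2.7-fold higher number from compound 2 to compound 4 (0.43 log units; beyond the scatter), the first measured step that differs in one place only. The six-membered aromatic ring of carbon is therefore not needed at this place for a readable dose, since compound 4 still gives 17.5 umol/kg, although activity does fall measurably with its removal. Compound 1 and compound 3 each differ from compound 2 in more than one place and each returns only a limit of the assay, so neither can be read against this step: the limit of > 100 umol/kg in this assay, at which 2 of the 4 values shown sit.

As far as these compounds go, a single step cannot show how the value changes with the size of the group on this amine nitrogen, and whether a propyl chain, a cyclohexyl or a benzyl group would fall between compound 2 and compound 4 remains open. Also open, from the compounds shown here alone, is whether the methyl compound keeps a readable dose with an ethyl ester or a primary amide in place of the carboxylic acid.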